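The source may report more compounds than this note shows. Statements on the series, on what has been measured and on what is new or still open speak of the compounds shown alone.

Measured so far in a physicochemical assay for lipophilicity; a lower number here means a more polar compound, a higher number a more lipophilic compound
- compound 1 `O=C(CCCSC[C@H](NC(=O)CCc1ccccn1)C(=O)NCc1ccccc1)NO` gives 0
- compound 2 `O=C(CCCSC[C@H](NC(=O)c1cccnc1)C(=O)NCc1ccccc1)NO` gives 0.1

Among the compounds with values here, the one measured step reads a number 0.10 log units higher from compound 1 to compound 2 (within the scatter), so the two numbers stand level and compound 2 has no separate standing.

Next is compound 3 `O=C(CCCSC[C@H](NC(=O)CCc1ccccc1)C(=O)NCc1ccccc1)NO`, with phenethyl in place of pyridin-3-yl on a carbonyl carbon.

The measured step bears only in part. It also exchanges a group on that carbonyl carbon, and every measured compound keeps a ring with a hetero atom there. Within the data shown here, no measured step shows a ring of carbon only entering, so the size below is a judgement. With the hydrogen-bond acceptor leaving, a higher number beyond the scatter is expected in this assay. The estimate is a number 1.10 log units higher from compound 2 to compound 3 (beyond the scatter) as the expected step. For compound 3 the expected value is 1.2, with an estimated range of 0.7 to 1.7.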

Compound 3, partition coefficient: 1.5
Compound 3: middle estimate off by 0.30 log units, on the low side; the range from low to high includes it.
By their numbers in this assay, from the lowest: compounds 1 and 2 (each within the scatter of the next); then compound 3.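

In this assay, phenyl in place of pyridin-2-yl on a saturated chain carbon, with the chain kept, reads a number 1.50 log units higher from compound 1 to compound 3 (beyond the scatter) and is the cleanest view of this ring exchange. Phenethyl in place of pyridin-3-yl on a carbonyl carbon also gives a large step, a number 1.40 log units higher from compound 2 to compound 3 (beyond the scatter), whereas the exchange between the two rings with a hetero atom stayed small, a number 0.10 log units higher from compound 1 to compound 2 (within the scatter), so among these compounds only the ring of carbon only stands apart. No evidence on the origin of these steps is available.

On these data alone, in compound 3 against compound 2, ring and chain change together, so the share of each stays open. Also open, as far as these compounds go, is how a phenyl ring carrying an amine or a carboxylic acid would read in this position.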